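Methyl to hydrogen on the saturated chain carbon

A few compounds are considered here, and "the series" means these few. Any claim that something is new, unique, unknown or untested is made for them only; others in the source may bear on it.

Measured so far:
compound 1 `COCC(C(=O)N1CCN(c2cccc(C(F)(F)F)c2)CC1)N1C(=O)CCC1=O` — 100%
compound 2 `CCC(C(=O)N1CCN(c2cccc(C(F)(F)F)c2)CC1)N1C(=O)CCC1=O` — 100%

Both measured compounds share one core and were tested in a functional assay on the whole organism (strain Swiss) with Mus musculus as the target, with a stated time of 0.25 h, at a dose of 300 mg/kg; a higher number here means a stronger effect of the compound at the dose given, a lower number a weaker effect. Compound 1 gives 100% and compound 2 gives 100%. Going by the values given here, the one measured step, no change at the digits printed from compound 1 to compound 2 (within the scatter), leaves the read-out where it was. Compound 2 therefore stands level with compound 1 at the digits shown, with nothing beyond the scatter between them.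

Compound 3 `CC(C(=O)N1CCN(c2cccc(C(F)(F)F)c2)CC1)N1C(=O)CCC1=O` has not been measured. It differs from compound 2 by hydrogen in place of methyl on a saturated chain carbon, two bonds along the chain from an amide-type nitrogen in a ring and a carbonyl carbon. The measured step touches the same chain carbon: there an exchange of methoxy for methyl gave no change at the digits printed from compound 1 to compound 2 (within the scatter). Compound 3 removes the group rather than exchanging it, so this single step is only a partial guide; how the read-out behaves once the carbon carries hydrogen is not shown by any measured pair.

Among the compounds with values here, with compound 2 at 100% and the one change at this carbon giving no change at the digits printed from compound 1 to compound 2 (within the scatter), a step of a number 8 percentage points lower from compound 2 to compound 3 (within the scatter) is expected, that is nothing beyond the scatter, while a loss cannot be excluded. For compound 3 the expected value is 92%, ranging from 55% to 100%.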

Compound 3, a percentage reported as activity, at one dose (the size of the read-out at that dose, not a potency): 100%
Compound 3: the middle estimate sits 8 percentage points below what was measured; low and high end bracket the measured number.
By their numbers in this assay, from the lowest: compounds 1, 2 and 3 (each within the scatter of the next).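

Working notes on the saturated chain carbon, two bonds along the chain from an amide-type nitrogen in a ring and a carbonyl carbon. In this assay, hydrogen in place of methyl gives no change at the digits printed from compound 2 to compound 3 (within the scatter) and hydrogen in place of methoxy gives no change at the digits printed from compound 1 to compound 3 (within the scatter), so the comparison now extends from exchanging one group for another to having no heavy atom on this carbon at all. Among these three compounds, the read-out at this dose therefore does not require a methyl or methoxy group at this position, and the shared core with hydrogen on this carbon is enough to give the full printed value. No measurement is available that would explain this result at the chain carbon.

Since compound 1, compound 2 and compound 3 all give the same printed value at a single dose, the read-out cannot show whether they would separate at lower doses, and it gives no potency for any of them. The compounds shown also leave open how this carbon behaves with a longer chain, a phenyl ring, an amine or a carboxylic acid in place of hydrogen.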